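From 3,4-dichlorophenyl to 2-bromophenyl

The source may report more compounds than this note shows. Statements on the series, on what has been measured and on what is new or still open speak of the compounds shown alone.

Compound 1 `COc1ccc(OCCCON2C(N)=NC(N)=NC23CCOCC3)cc1` gives 660 nM
Compound 2 `NC1=NC2(CCOCC2)N(OCCCOc2ccc(Cl)c(Cl)c2)C(N)=N1` gives 790 nM

Among the compounds with values here, in a functional assay on A549 cells (Homo sapiens) for antiproliferative activity, read by MTT assay, with a stated time of 72 h (on this read-out lower numbers stand for stronger inhibition and higher numbers for weaker inhibition), compound 2 gives 790 nM and stands level, within the scatter, with compound 1, the only other measured compound. Compound 3 `NC1=NC2(CCOCC2)N(OCCCOc2ccccc2Br)C(N)=N1` differs by 2-bromophenyl in place of 3,4-dichlorophenyl on an oxygen on a saturated carbon with 2-bromophenyl in place of 3,4-dichlorophenyl on an oxygen on a saturated carbon. Within the data shown here, the one measured step bearing on this is a 1.2-fold higher number from compound 1 to compound 2 (0.08 log units; within the scatter) and it changed the group at that same place, staying within the scatter. No step beyond the scatter is therefore expected in this assay for this change, though one step is thin evidence. The expected step is a 1.1-fold lower number from compound 2 to compound 3 (0.02 log units; within the scatter) and no larger. Compound 3 is estimated at 750 nM with 300 nM to 1900 nM as its expected range.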

Compound 3, half-maximal inhibitory concentration: 160 nM
The estimate for compound 3 lay 4.7-fold (0.67 log units) above the measured number; the measured number lies below the stated range.
By their numbers in this assay, from the lowest: compound 3; then compounds 1 and 2 (each within the scatter of the next).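

In this assay the change to 2-bromophenyl gives a 4.9-fold lower number from compound 2 to compound 3 (0.69 log units; beyond the scatter) and the change from 4-methoxyphenyl gives a 4.1-fold lower number from compound 1 to compound 3 (0.62 log units; beyond the scatter) on the same oxygen, whereas compound 1 and compound 2 had stood level within the scatter. The aryl group at this place can therefore move the number beyond the scatter, which the first pair did not show. Nothing available here accounts for the step.

The compounds shown leave open whether a 2-chlorophenyl or a 4-bromophenyl group would match 2-bromophenyl. They also leave open how an unsubstituted phenyl would compare.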